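Working notes: carboxy in place of nitro

The compounds below may be only part of what the source reports. "The series", "measured", "known", "first", "only" and "open" are said of these compounds alone.

Of the compounds shown here, three sharing one core have been read so far. Compound 1 (`Nc1n[nH]c(N)c1/N=N/c1cccc2c1CCCC2`) gives 77000 nM in a functional assay on G-361 cells (Homo sapiens) for antiproliferative activity (on this read-out higher numbers stand for weaker inhibition and lower numbers for stronger inhibition), and is the only one of the three with a numeric result. Compound 2 (`Nc1n[nH]c(N)c1/N=N/c1ccc([N+](=O)[O-])cc1`) returns > 100000 nM as a limit of the assay and not a number. Compound 3 (`Nc1n[nH]c(N)c1/N=N/c1cccc(O)c1`) returns > 100000 nM as a limit of the assay as well. Compound 2 therefore has no exact place in the series and stands at the limit of > 100000 nM in this assay, at which 2 of the 3 values shown sit, in this small set.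

Compound 4 (`Nc1n[nH]c(N)c1/N=N/c1ccc(C(=O)O)cc1`) is still to be read. Its difference from compound 2 is carboxy in place of nitro on an aromatic carbon with carboxy in place of nitro, on an aromatic carbon of a six-membered aromatic ring of carbon only, para to a group of 9 heavy atoms. Within the data shown here, no measured step bears on this change, so in this assay no shift beyond the scatter is expected in either direction. This expectation starts from compound 2, whose > 100000 nM is a limit of the assay. The estimated a number no higher from compound 2 to compound 4 (the limit leaves the size open) stays within the scatter. For compound 4 the estimate is 100000 nM with an expected range from 45000 nM to 200000 nM and a report at the assay limit is considered likely.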

Compound 4, half-maximal inhibitory concentration: > 100000 nM
Compound 4 was reported as a limit (the forecaster's own chance of this, stated with the estimate: 75%); the middle value lies on the limit itself.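

Compound 2 and compound 4 are both reported only as limits of the assay in this assay, so carboxy in place of nitro on an aromatic carbon gives no readable step. Both stand at the same point: the limit of > 100000 nM in this assay, at which 3 of the 4 values shown sit.

The compounds shown leave open whether this exchange shifts the read-out at all, and in which direction.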